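Removing the Chloro Group from a Series Stuck at the Limit

This account rests on a few compounds, and the source may have more. Where it says the series, first, only, none or still open, it means among the compounds named here.

Compound 1 `COc1ccc(Cl)cc1N(CC(=O)N1CCc2ccccc21)S(=O)(=O)c1ccccc1`: in a functional assay on SH-SY5Y cells (Homo sapiens), read by MTT assay, with a stated time of 24 h (on this read-out lower numbers stand for an effect already at smaller amounts and higher numbers for an effect only at larger amounts of compound), compound 1 gives only the limit > 20000 nM.
Compound 2 `CCN(CC)C(=O)CN(c1cc(Cl)ccc1OC)S(=O)(=O)c1ccccc1`: compound 2 gives only the limit > 20000 nM.
Compound 3 `COc1ccc(Cl)cc1NC(=O)CN(c1cc(Cl)ccc1OC)S(=O)(=O)c1ccccc1`: compound 3 gives only the limit > 20000 nM.

The three measured compounds share one core and differ only in the group on a carbonyl carbon. Compound 3 therefore stands on no real number: the limit of > 20000 nM in this assay, at which 3 of the 3 values shown sit. The steps a step that the two limits leave unreadable from compound 1 to compound 2, a step that the two limits leave unreadable from compound 1 to compound 3 and a step that the two limits leave unreadable from compound 2 to compound 3 show nothing about size. Every value involved is a limit.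

Compound 4 `COc1ccccc1NC(=O)CN(c1cc(Cl)ccc1OC)S(=O)(=O)c1ccccc1` differs from compound 3 by a single small change: hydrogen in place of chloro on an aromatic carbon. Within the data shown here, no measured step touches the chloro group, and the three measured steps bear on this one only by showing that every change made so far has left the read-out at the limit. The step is expected to be a step that the limit leaves unreadable from compound 3 to compound 4, which a limit cannot resolve. For compound 4 the estimate in this assay is 30000 nM, within 10000 nM to 100000 nM, with another limit the most likely outcome.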

Compound 4, half-maximal effective concentration: 15500 nM
Beside the measured number, compound 4's estimate is 1.9-fold (0.29 log units) above it, within the range that was stated.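

In this assay, compound 4 is the only compound shown with a real number rather than a limit, so the size of its steps can be stated only as floors because the other three compounds stand on a limit: the limit of > 20000 nM in this assay, at which 3 of the 4 values shown sit.
Hydrogen in place of chloro, para to a methoxy group, gives an at least 1.2-fold lower number from compound 3 to compound 4 (0.11 log units; that floor lies within the scatter), so this change is the first to bring the read-out off the limit, though the floor alone does not establish a real drop. The comparisons at the carbonyl carbon give an at least 1.2-fold lower number from compound 2 to compound 4 (0.11 log units; that floor lies within the scatter) and an at least 1.2-fold lower number from compound 1 to compound 4 (0.11 log units; that floor lies within the scatter), while the steps among compound 1, compound 2 and compound 3 cannot be read.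

From the compounds shown here alone, how large the true change is remains open. So does whether fluoro or a methyl group at the same ring position would give a number like that of hydrogen or return the read-out to the limit.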